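The compounds below may be only part of what the source reports. "The series", "measured", "known", "first", "only" and "open" are said of these compounds alone.

Measured in a functional assay (Saphenous vein) for binding affinity, with Oryctolagus cuniculus as the target; a lower number here means tighter binding, a higher number weaker binding:
compound 1 `Cc1nc(Cc2ccc3[nH]cc([C@H]4C[C@H](N(C)C)C4)c3c2)n[nH]1`: 6610 nM
compound 2 `CN(C)[C@H]1C[C@H](c2c[nH]c3ccc(CC(N)=O)cc32)C1`: 16600 nM

Of these two, compound 2 has the higher number, 16600 nM, and so the weaker binding. Compound 3 `CN(C)[C@H]1C[C@H](c2c[nH]c3ccc(Oc4ccccc4)cc32)C1` has phenoxy in place of carbamoylmethyl on an aromatic carbon. Going by the values given here, only one measured step bears on this change: a 2.5-fold higher number from compound 1 to compound 2 (0.40 log units; beyond the scatter). This modest step, beyond the scatter, puts carbamoyl in place of 5-methyl-1H-1,2,4-triazol-3-yl. The ring-bearing compound 1 gives the lower number, 6610 nM, and compound 3 also brings in a ring. That ring is a different one, attached differently, so the guide is thin. A modest move toward a lower number in this assay is therefore expected, with wide uncertainty. The expected change is a 2.8-fold lower number from compound 2 to compound 3 (0.44 log units; beyond the scatter). The estimated value for compound 3 is 6000 nM, within an expected range of 1000 nM to 30000 nM.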

Compound 3, dissociation constant: 240 nM
The estimate for compound 3 lay 25-fold (1.40 log units) above the measured number, outside the stated range (below it).
By their numbers in this assay, from the lowest: compound 3; then compound 1; then compound 2.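

In this assay the group on this aromatic carbon can move the number much further than the modest earlier step suggested: phenoxy in place of carbamoylmethyl gives a 69-fold lower number from compound 2 to compound 3 (1.84 log units; beyond the scatter) and phenoxy in place of (5-methyl-1H-1,2,4-triazol-3-yl)methyl gives a 28-fold lower number from compound 1 to compound 3 (1.44 log units; beyond the scatter) as a second large change. Since compound 1 also carries a ring in this group, the presence of a ring alone does not account for the low number of compound 3, and the ring's kind or its attachment may matter as well. No measurement at hand explains why phenoxy stands so far apart from the other two groups.

The compounds shown leave open whether the ether oxygen or the benzene ring matters more, which benzyl or phenyl at this carbon would help to separate. They also leave open how a chloro or methoxy group on the phenoxy ring would change the number.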